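This account rests on a few compounds, and the source may have more. Where it says the series, first, only, none or still open, it means among the compounds named here.

Compound 1 `COc1ccc(C(F)(F)F)cc1CO[C@H]1[C@H](C(C)(C)C)[C@@H](C(=O)O)N(C(=O)C2CCCCC2)[C@H]1c1ccccc1` gives 590%.
Compound 2 `COc1ncc(C(F)(F)F)cc1CO[C@H]1[C@H](C(C)(C)C)[C@@H](C(=O)O)N(C(=O)C2CCCCC2)[C@H]1c1ccccc1` gives 650%.
Compound 3 `COc1ncc(C(C)(C)C)cc1CO[C@H]1[C@H](C(C)(C)C)[C@@H](C(=O)O)N(C(=O)C2CCCCC2)[C@H]1c1ccccc1` gives 455%.

In an assay on cells with Cystic fibrosis transmembrane conductance regulator variant F508del (Homo sapiens) as the target, read by voltage clamp, with a stated time of 24 h, in the presence of a further agent that is not named here (a lower number here means a smaller maximal response, a higher number a larger maximal response), compound 2 stands highest of the three numbers, with compound 1 nearest and compound 3 furthest. The measured steps are a number 60 percentage points higher from compound 1 to compound 2 (beyond the scatter), a number 135 percentage points lower from compound 1 to compound 3 (beyond the scatter) and a number 195 percentage points lower from compound 2 to compound 3 (beyond the scatter), all of them beyond the scatter and all concerning the group on the saturated chain carbon bound to an oxygen on a saturated carbon.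

Compound 4 `COc1ncc(C(F)(F)F)cc1CO[C@H]1[C@H](C(C)(C)C)[C@@H](C(=O)O)N(C(=O)OC(C)C)[C@H]1c1ccccc1` differs from compound 2 elsewhere: isopropoxy in place of cyclohexyl on a carbonyl carbon. None of the three measured steps touches the group on this carbonyl carbon, so they give no direct guide to the size or direction of this change; the measured steps only show that the maximal response in this series is sensitive to single-group exchanges. Compound 4 is therefore expected to stay in the same broad range as compound 2, with a wide margin of uncertainty, and the estimated step is a number 100 percentage points lower from compound 2 to compound 4 (beyond the scatter). The estimate for compound 4 is 550%, within 350% to 750%.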

Compound 4, largest response reached (Emax), in percent of the reference or control that the assay uses: 438%
For compound 4 the middle estimate is 112 percentage points above the measured one, within the range that was stated.
By their numbers in this assay, from the lowest: compound 4; then compound 3; then compound 1; then compound 2.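

In this assay, among the compounds shown here, the exchange of cyclohexyl for isopropoxy on the carbonyl carbon gives a number 212 percentage points lower from compound 2 to compound 4 (beyond the scatter), which shows that the group at this place, unchanged among the earlier compounds, also shapes the maximal response. A single exchange here lowers the number by an amount of the same order as the exchange of trifluoromethyl for tert-butyl on the aromatic carbon, a number 195 percentage points lower from compound 2 to compound 3 (beyond the scatter). Nothing available explains why the response falls with this change.

The step removes the ring and brings in an oxygen together, so the compounds shown cannot tell which of the two goes with the fall; an isopropyl or a cyclohexyloxy group on the same carbonyl carbon would separate them. Going by these compounds, whether isopropoxy gives a similar step alongside the 2-methoxy-5-(trifluoromethyl)phenyl group of compound 1 also stays open.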